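The compounds below may be only part of what the source reports. "The series", "measured", "known", "first", "only" and "open" are said of these compounds alone.

Measured so far in a functional assay, read by spectrophotometry, with a stated time of 30 min; a lower number here means a stronger inhibitor, a higher number a weaker inhibitor:
compound 1 `Cc1nc2c3ccccc3ccc2c2nc3c(ccc4ccccc43)c(-c3nccnc3N)c12`: 81.7 ug/mL
compound 2 `Cc1nc2c3ccccc3ccc2c2nc3c(ccc4ccccc43)c(-c3ccc(O)cc3)c12`: 86.4 ug/mL
compound 3 `Cc1nc2c3ccccc3ccc2c2nc3c(ccc4ccccc43)c(-c3cc(O)nc4ccccc34)c12`: 92.1 ug/mL

Compound 3 sits inside the same band as the other two: the steps of a 1.1-fold higher number from compound 2 to compound 3 (0.03 log units; within the scatter) and a 1.1-fold higher number from compound 1 to compound 3 (0.05 log units; within the scatter) both lie within the scatter, as does a 1.1-fold higher number from compound 1 to compound 2 (0.02 log units; within the scatter). All three measured steps exchange one aromatic group for another at the same carbon, and none of them moves the number beyond the scatter.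

Compound 4 `Cc1nc2c3ccccc3ccc2c2nc3c(ccc4ccccc43)c(C)c12` differs from compound 3 by methyl in place of 2-hydroxyquinolin-4-yl on an aromatic carbon. For the measured compounds named here, no measured step removes the aromatic group altogether, so none bears directly on this change; the nearest evidence is that three different groups at this carbon give numbers within the scatter of each other. The expected step is therefore small, a 1.0-fold higher number from compound 3 to compound 4 (0.01 log units; within the scatter), with wide uncertainty. Compound 4 is estimated at 95 ug/mL in this assay, range 45 ug/mL to 200 ug/mL.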

Compound 4, half-maximal inhibitory concentration: 129 ug/mL
Compound 4: the middle estimate sits 1.4-fold (0.13 log units) below what was measured; the range from low to high includes it.
By their numbers in this assay, from the lowest: compounds 1, 2, 3 and 4 (each within the scatter of the next).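

In this assay, methyl in place of each aromatic group at this carbon stays within the scatter: a 1.4-fold higher number from compound 3 to compound 4 (0.15 log units; within the scatter), a 1.5-fold higher number from compound 2 to compound 4 (0.17 log units; within the scatter) and a 1.6-fold higher number from compound 1 to compound 4 (0.20 log units; within the scatter). This carbon therefore accepts the loss of the whole 2-hydroxyquinolin-4-yl, with both its rings, without a step beyond the scatter, so no aromatic group here is shown to be needed. No measured evidence bears on these small steps.

As far as these compounds go, whether an amine, a carboxylic acid or a longer chain at this carbon would move the number beyond the scatter stays open. The compounds shown also leave open whether changes to the shared core would do so.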